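Swapping Methoxy for Nitro on the Urea Phenyl

The compounds below may be only part of what the source reports. "The series", "measured", "known", "first", "only" and "open" are said of these compounds alone.

Of the compounds shown here, three built on a shared core have been tested in a functional assay on HepG2 cells (Homo sapiens) for antiproliferative activity, read by MTT assay; a higher number here means a weaker inhibitor, a lower number a stronger inhibitor. Compound 1 `O=C(Nc1cccc(CNc2ncnc3ccccc23)c1)Nc1ccccc1F` gives 17500 nM in this assay, and compound 2 `O=C(Nc1ccc(F)cc1)Nc1cccc(CNc2ncnc3ccccc23)c1` gives 41500 nM. Their one difference is the measured step of a 2.4-fold higher number from compound 1 to compound 2 (0.38 log units; beyond the scatter). Compound 3 `COc1ccc(NC(=O)Nc2cccc(CNc3ncnc4cc(OC)c(OC)cc34)c2)cc1` reaches only a limit of the assay, > 50000 nM. That value is described as the limit of > 50000 nM in this assay, at which 1 of the 3 values shown sits, so where compound 3 truly stands is not known.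

Compound 4 `COc1cc2ncnc(NCc3cccc(NC(=O)Nc4ccc([N+](=O)[O-])cc4)c3)c2cc1OC` differs from compound 3 by nitro in place of methoxy on an aromatic carbon, para to a large group. Among the measured compounds shown here, the only measured step moves a fluorine on a different phenyl and was modest, so it says little about this change. Compound 4 is expected to give roughly 45000 nM, between 12000 nM and 150000 nM. The expected step is an at least 1.1-fold lower number from compound 3 to compound 4 (0.04 log units; that floor lies within the scatter), with no direction beyond the scatter firmly supported.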

Compound 4, half-maximal inhibitory concentration: 18800 nM
Estimate against measurement, compound 4: 2.4-fold (0.38 log units) above, and the stated range covers the measured number.
By their numbers in this assay, from the lowest: compounds 1 and 4 (each within the scatter of the next); then compound 2. At a limit, above all of these: compound 3.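

In this assay, replacing 4-methoxyphenyl with 4-nitrophenyl gives an at least 2.6-fold lower number from compound 3 to compound 4 (0.42 log units; beyond the scatter). Among the compounds shown here, this is the first sign that the group at this place on the ring, para to a large group, can shift the number beyond the scatter; the earlier fluorine step concerned a different change. The true size of the step stays unknown, because compound 3 stands at a limit: the limit of > 50000 nM in this assay, at which 1 of the 4 values shown sits.

The compounds shown leave open how an amine or a carboxylic acid would read at this same place. They also leave open whether nitro would give a similar step on the core of compound 1.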